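Cyano substitution on the pyrazole carbamoyl series, brain membranes

The compounds below may be only part of what the source reports. "The series", "measured", "known", "first", "only" and "open" are said of these compounds alone.

Measured in an assay on membranes from brain for binding affinity to neutral cholesterol ester hydrolase 1 (Mus musculus), read by fluorescence, with stated times of 1 h and 30 min; a higher number here means a weaker inhibitor, a lower number a stronger inhibitor:
compound 1, `CN(CCN(C)C(=O)n1cccn1)Cc1cccc(OCc2ccccc2)c1`, reports only a limit, > 100000 nM
compound 2, `CN(CCN(C)C(=O)n1cc(C#N)cn1)Cc1cccc(OCc2ccccc2)c1`, reports only a limit, > 100000 nM
compound 3, `O=C(NCc1ccc(OC(c2ccccc2)c2ccccc2)cc1)n1cccn1`, reports only a limit, > 100000 nM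

Compound 1 and compound 2 share a core and differ by cyano in place of hydrogen on an aromatic carbon. The step that the two limits leave unreadable from compound 1 to compound 2 cannot be read as a size, because of the limit of > 100000 nM in this assay, at which 3 of the 3 values shown sit. Compound 3 carries a different core; the difference between the two cores is not broken down here. Compound 4, `N#Cc1cnn(C(=O)NCc2ccc(OC(c3ccccc3)c3ccccc3)cc2)c1`, is not yet measured; it stands to compound 3 as compound 2 stands to compound 1, with the change (cyano in place of hydrogen on an aromatic carbon), the same change at the same place, occurring twice in the set.

For compound 4 in this assay the expected step is a step that the limit leaves unreadable from compound 3 to compound 4 beside the earlier one. This expectation rests on compound 3, whose value > 100000 nM is a limit, and on (the limit of > 100000 nM in this assay, at which 3 of the 3 values shown sit), at which all three values sit. Compound 4 is therefore estimated at 150000 nM, most probably again reported as a limit rather than a number, with a range from 30000 nM to 1000000 nM.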

Compound 4, half-maximal inhibitory concentration: > 100000 nM
Compound 4: only a limit was reported (the forecaster's own chance of this, stated with the estimate: 85%); the middle value lies beyond the limit too.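

In this assay compound 4 gives only a limit, > 100000 nM, so neither the cyano step from compound 3 to compound 4 nor the one from compound 1 to compound 2 can be read as a size: the limit of > 100000 nM in this assay, at which 4 of the 4 values shown sit.

The compounds shown leave open whether cyano in place of hydrogen changes inhibition in either pair, and how the two cores compare.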